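Ring-closed amide in a stilbene-pyridine series

The compounds below may be only part of what the source reports. "The series", "measured", "known", "first", "only" and "open" are said of these compounds alone.

Compound 2 `O=C(NC1CC1)c1cc(Oc2ccc(/C=C/c3ccccn3)cc2)ccn1` shares its core with compound 1 `CNC(=O)c1cc(Oc2ccc(/C=C/c3ccccn3)cc2)ccn1` and differs from it only at the amide-type nitrogen. In a functional assay on HepG2 cells (Homo sapiens) for antiproliferative activity, read by CCK-8 assay, with a stated time of 48 h (on this read-out higher numbers stand for weaker inhibition and lower numbers for stronger inhibition), compound 1 gives 21600 nM, and compound 2 gives 31000 nM. Of the two numbers, compound 2 holds the higher one, but the step of a 1.4-fold higher number from compound 1 to compound 2 (0.16 log units; within the scatter) is within the scatter, so the two compounds cannot be told apart. Compound 3 `O=C(c1cc(Oc2ccc(/C=C/c3ccccn3)cc2)ccn1)N1CCCC1` changes the same position again: pyrrolidin-1-yl in place of cyclopropylamino on a carbonyl carbon. For the measured compounds named here, the one measured step, that from compound 1 to compound 2, bears on it only loosely, since it swapped one substituent on that nitrogen for another and left the hydrogen-bond donor in place, whereas here the donor disappears. With no step beyond the scatter on record, the expectation for compound 3 is a step of a 1.1-fold higher number from compound 2 to compound 3 (0.05 log units; within the scatter), amounting to no clear change. Compound 3 is therefore estimated at 35000 nM, with a range from 12000 nM to 100000 nM.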

Compound 3, half-maximal inhibitory concentration: 27000 nM
Estimate against measurement, compound 3: 1.3-fold (0.11 log units) above; the measured number falls inside the stated range.
By their numbers in this assay, from the lowest: compounds 1, 3 and 2 (each within the scatter of the next).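

The hydrogen-bond donor on the amide nitrogen is gone in compound 3, yet in this assay the step is a 1.1-fold lower number from compound 2 to compound 3 (0.06 log units; within the scatter), and against the smaller methylamino amide it is a 1.3-fold higher number from compound 1 to compound 3 (0.10 log units; within the scatter). Among these three compounds, then, the amide hydrogen makes no difference that this assay can detect, and pyrrolidin-1-yl on the carbonyl carbon cannot be told apart from cyclopropylamino or methylamino. No measurement at hand offers an explanation for this result.

For the compounds shown here, it remains open whether any group at this position can shift the number beyond the scatter, since all three steps so far lie within it. A longer chain ending in an amine, a morpholin-4-yl group, or a carboxylic acid in place of the amide would test this position more widely.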